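The source may hold more compounds than are shown below. What is called first, only, known or untested is meant among the compounds shown, and "the series" means these compounds.

Measured so far in an assay on kidney for binding affinity to tissue alpha-L-fucosidase (Homo sapiens); on this read-out lower numbers stand for stronger inhibition and higher numbers for weaker inhibition:
- Compound 1, `CCNC1CC(C)C(O)C(O)C1O`: 180 nM
- Compound 2, `CCCCNC1CC(C)C(O)C(O)C1O`: 74 nM
- Compound 3, `CCCCCCCNC1CC(C)C(O)C(O)C1O`: 48 nM

Compound 3 gives the lowest number of the three in this assay. Its gap to compound 1 is beyond the scatter, as a 3.8-fold lower number from compound 1 to compound 3 (0.57 log units; beyond the scatter) shows; its gap to compound 2 is not, since a 1.5-fold lower number from compound 2 to compound 3 (0.19 log units; within the scatter) lies within the scatter, so compound 3 and compound 2 cannot be ordered against each other.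

Compound 4, `CC1CC(NCc2ccccc2)C(O)C(O)C1O`, differs from compound 3 in that (phenyl in place of hexyl on a saturated chain carbon bound to an amine nitrogen). Among the measured compounds shown here, no measured step swaps a chain for an aromatic ring; the three steps at hand only lengthen the chain on the amine nitrogen. Those steps were modest at best: a 2.4-fold lower number from compound 1 to compound 2 (0.39 log units; beyond the scatter) and a 3.8-fold lower number from compound 1 to compound 3 (0.57 log units; beyond the scatter), while a 1.5-fold lower number from compound 2 to compound 3 (0.19 log units; within the scatter) stayed within the scatter. Compound 4 keeps a substituent of the same heavy-atom count on that carbon, so no step beyond the scatter is expected in this assay; the estimated step is a 1.7-fold higher number from compound 3 to compound 4 (0.22 log units; within the scatter). Compound 4 is therefore expected to give about 80 nM, with a range from 25 nM to 250 nM.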

Compound 4, inhibition constant: 69 nM
The estimate for compound 4 lay 1.2-fold (0.06 log units) above the measured number; low and high end bracket the measured number.
By their numbers in this assay, from the lowest: compounds 3, 4 and 2 (each within the scatter of the next); then compound 1.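

In this assay, putting phenyl in place of hexyl on a saturated chain carbon bound to an amine nitrogen stays within the scatter, at a 1.4-fold higher number from compound 3 to compound 4 (0.16 log units; within the scatter), and phenyl in place of propyl does too, at a 1.1-fold lower number from compound 2 to compound 4 (0.03 log units; within the scatter). Among the compounds shown here, an aromatic ring at this place therefore cannot be told apart from the two longer chains, so the numbers so far do not depend on the substituent being a chain; only against methyl does phenyl show a modest step beyond the scatter, at a 2.6-fold lower number from compound 1 to compound 4 (0.42 log units; beyond the scatter). Nothing at hand explains this result.

The compounds shown leave open whether cyclohexyl at this place would fall in the same range. They also leave open whether a pyridyl ring, or a phenyl carrying a hydroxyl, would move the number beyond the scatter.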